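The compounds below may be only part of what the source reports. "The series", "measured", "known", "first", "only" and "open" are said of these compounds alone.

Compound 1 `CCC(=O)N(c1ccc(Cl)cc1)C1CCCC1N(C)C` is the starting point in a functional assay on the whole organism for positive allosteric modulation, with Mus musculus as the target; on this read-out lower numbers stand for an effect already at smaller amounts and higher numbers for an effect only at larger amounts of compound. In this assay compound 1 gives > 50 mg/kg, which is a limit of the assay and not a number, so its position is fixed only at that limit (the limit of > 50 mg/kg in this assay, at which 1 of the 2 values shown sits). Compound 3 `CCC(=O)N(c1ccc(Cl)c(C)c1)C1CCCC1N(C)C` differs from it by methyl in place of hydrogen on an aromatic carbon, ortho to a chloro group and meta to a large group (methyl in place of hydrogen on an aromatic carbon). For the measured compounds named here, the only full number nearby comes from compound 2 `CCC(=O)N(c1cccc(C)c1)C1CCCC1N(C)C`, which carries a methyl group and no chloro group and gives 25 mg/kg; 25 mg/kg (2 entries). On that value, a shift towards smaller doses is expected, of moderate size and with a real chance that a limit is returned again. The expected step is an at least 1.6-fold lower number from compound 1 to compound 3 (0.22 log units; that floor lies within the scatter). For compound 3 the estimated dose is 30 mg/kg, with an expected range from 12 mg/kg to 70 mg/kg.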

Compound 3, dose for half-maximal effect: 10 mg/kg
For compound 3 the middle estimate is 3.0-fold (0.48 log units) above the measured one; measured number outside the range, below it.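

In this assay, this single change moves the chloro compound from a limit to a full number, and the step is an at least 5.0-fold lower number from compound 1 to compound 3 (0.69 log units; beyond the scatter). With the chloro group in place, methyl on this aromatic carbon therefore counts as a gain beyond the scatter and not as a neutral change. The size of that gain is only a lower bound, because compound 1 stands at a limit and not at a number: the limit of > 50 mg/kg in this assay, at which 1 of the 3 values shown sits.

A single step leaves open whether the gain is particular to methyl or would also hold for a longer chain such as ethyl, or for a methoxy group or an amine on the same carbon. It also leaves open how much of the gain depends on the chloro group that compound 3 carries.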